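Fluorine Added Beside a Trifluoromethyl Group on a Diaryl Urea

This account rests on a few compounds, and the source may have more. Where it says the series, first, only, none or still open, it means among the compounds named here.

Measured so far in a functional assay on MDA-MB-231 cells (Homo sapiens) for inhibition, read by MTT assay and WST assay, with a stated time of 72 h, tested at 10 uM; on this read-out higher numbers stand for more inhibition of growth at the one concentration tested and lower numbers for less inhibition of growth:
Compound 1, `O=C(Nc1ccc(Cl)cc1)Nc1ccc(Oc2ccc(-c3ncc[nH]3)cc2)cc1`, compound 1 gives 47.6%.
Compound 2, `O=C(Nc1ccc(Oc2ccc(-c3ncc[nH]3)cc2)cc1)Nc1ccc(Cl)c([N+](=O)[O-])c1`, compound 2 gives 3.36%.
Compound 3, `O=C(Nc1ccc(Oc2ccc(-c3ncc[nH]3)cc2)cc1)Nc1cccc(C(F)(F)F)c1`, compound 3 gives 28.1%.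

Compound 3 stands second highest of the three on this read-out; its nearest neighbour is compound 1, which sits higher (a number 19.5 percentage points lower from compound 1 to compound 3 (beyond the scatter)), and the furthest is compound 2, which sits lower (a number 24.7 percentage points higher from compound 2 to compound 3 (beyond the scatter)).

Compound 4, `O=C(Nc1ccc(Oc2ccc(-c3ncc[nH]3)cc2)cc1)Nc1ccc(F)c(C(F)(F)F)c1`, differs from compound 3 in one place: fluoro in place of hydrogen on an aromatic carbon.

Going by the values given here, no measured step adds a fluoro group, so the evidence is indirect. Among the compounds with values here, the one step that adds a single group to an aromatic carbon is a number 44.2 percentage points lower from compound 1 to compound 2 (beyond the scatter), a large loss, but that group is a nitro, not a fluoro. The two steps that swap the whole aryl group, a number 19.5 percentage points lower from compound 1 to compound 3 (beyond the scatter) and a number 24.7 percentage points higher from compound 2 to compound 3 (beyond the scatter), are modest. A single fluoro beside an already present trifluoromethyl is a smaller change than any of these, so the expected step in this assay is small, likely within the scatter, with a slight lean downward.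

Compound 4 is therefore estimated at 24%, with a range from 6% to 42%, an expected step of a number 4.1 percentage points lower from compound 3 to compound 4 (within the scatter).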

Compound 4, percent growth inhibition at one concentration: 26.6%
Beside the measured number, compound 4's estimate is 2.6 percentage points below it, and the stated range covers the measured number.
By their numbers in this assay, from the lowest: compound 2; then compounds 4 and 3 (each within the scatter of the next); then compound 1.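

The first direct test of a fluoro on this ring comes in this assay, where a number 1.5 percentage points lower from compound 3 to compound 4 (within the scatter), so compound 3 and compound 4 cannot be told apart. A hydrogen on this aromatic carbon, ortho to a trifluoromethyl group and para to a large group, can therefore be exchanged for one fluoro with no change that this read-out can detect, unlike the nitro step from compound 1 to compound 2, which added a different group at a different place. The larger aryl swaps remain beyond the scatter, with a number 23.2 percentage points higher from compound 2 to compound 4 (beyond the scatter) and a number 21 percentage points lower from compound 1 to compound 4 (beyond the scatter), while nothing available here explains why this fluoro leaves the number where it was.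

As far as these compounds go, it remains open whether a methoxy group or an amine on this same carbon would be tolerated as well as fluoro is. The compounds shown also leave open whether a fluoro would behave the same way on the 4-chlorophenyl group of compound 1, where the number in this assay starts from a different level.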